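Chloro for trifluoromethyl on the benzylsulfanyl arm

A few compounds are considered here, and "the series" means these few. Any claim that something is new, unique, unknown or untested is made for them only; others in the source may bear on it.

Measured compounds:
compound 1, `Cc1cc(S(=O)(=O)/N=C(\N)N/N=C/C#Cc2ccccc2)c(SCc2ccccc2C(F)(F)F)cc1Cl`, 0.653 h
compound 2, `C/C(C#Cc1ccccc1)=N\N/C(N)=N/S(=O)(=O)c1cc(C)c(Cl)cc1SCc1cccc(C(F)(F)F)c1`, 0.13 h

Of the compounds shown here, two have been measured in an ADME assay on microsomes from liver (Homo sapiens) for metabolic stability, read by LC-MS, using NADPH, tested at 5 uM; a higher number here means that the compound lasts longer, a lower number that the compound disappears faster. Compound 1 gives 0.653 h. Compound 2 gives 0.13 h, the lower of the two numbers; the gap to compound 1 lies beyond the usual scatter, though the two compounds differ in more than one place, so no single change can be read from that gap.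

Compound 3, `C/C(C#Cc1ccccc1)=N\N/C(N)=N/S(=O)(=O)c1cc(C)c(Cl)cc1SCc1cccc(Cl)c1`, is the next compound to be measured in this assay. It differs from compound 2 in one place: chloro in place of trifluoromethyl on an aromatic carbon.

Among the measured compounds shown here, no step between measured compounds isolates this change, so the size and direction of its effect are not known from the data at hand. The account therefore expects only a small step, a 1.2-fold higher number from compound 2 to compound 3 (0.06 log units; within the scatter), within the scatter, with the direction open. The estimated half-life of compound 3 in this assay is 0.15 h, expected to fall between 0.06 h and 0.4 h.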

Compound 3, half-life: 0.596 h
Beside the measured number, compound 3's estimate is 4.0-fold (0.60 log units) below it; measured number outside the range, above it.
By their numbers in this assay, from the lowest: compound 2; then compounds 3 and 1 (each within the scatter of the next).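

In this assay, among the compounds shown here, this is the first change that can be read on its own, as the two earlier compounds differ in more than one place, and it is not a small one: a 4.6-fold higher number from compound 2 to compound 3 (0.66 log units; beyond the scatter) with chloro in place of trifluoromethyl on an aromatic carbon. In this setting, then, the (3-(trifluoromethyl)benzyl)sulfanyl and (3-chlorobenzyl)sulfanyl groups are not interchangeable, and the one with chloro gives the longer half-life of the pair. The data at hand offer no measurement that accounts for this step.

Only these two groups are shown at this place, so it stays open whether the step reflects the arrival of chloro or the departure of trifluoromethyl, a question that plain hydrogen, fluoro, methyl or methoxy there could help to settle. Also open, going by these compounds, is whether the same exchange would bring a step of similar size and direction in the setting of compound 1, where the trifluoromethyl group sits elsewhere on the ring and the chain at the other end of the molecule also differs.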